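Adding a Nitro Group to an Anilide Chalcone

The source may hold more compounds than are shown below. What is called first, only, known or untested is meant among the compounds shown, and "the series" means these compounds.

Measured so far:
- compound 1 `Nc1ccc(C(=O)/C=C/c2ccccc2)cc1`: 27000 nM
- compound 2 `O=C(/C=C/c1ccccc1)c1ccc(NC(=O)c2cccs2)cc1`: 12000 nM

Both compounds were tested in a functional assay on HCT-116 cells (Homo sapiens) for cytotoxicity, read by resazurin assay, with a stated time of 48 h; a lower number here means that less compound is needed, a higher number that more compound is needed for the effect. Compound 1 gives 27000 nM. Within the data shown here, compound 2 gives 12000 nM, and the one measured step, a 2.3-fold lower number from compound 1 to compound 2 (0.35 log units; beyond the scatter), comes from placing a (thiophen-2-yl)carbonyl in place of hydrogen on a nitrogen on an aromatic ring. Compound 2 therefore holds the lowest of the two numbers, with compound 1 the nearest at a higher value.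

Compound 3 `O=C(/C=C/c1cccc([N+](=O)[O-])c1)c1ccc(NC(=O)c2cccs2)cc1` is the next compound. Its difference from compound 2 is:
nitro in place of hydrogen on an aromatic carbon
Cut one bond further out, this reads as phenyl to 3-nitrophenyl, on the ring at the far end of the shared core.

Among the measured compounds shown here, no measured step bears on this change. The step of a 2.3-fold lower number from compound 1 to compound 2 (0.35 log units; beyond the scatter) concerns the nitrogen on the other aromatic ring, not the carbon ring that receives the nitro, so it gives no guide to size or direction here. Without a relevant precedent, no step beyond the scatter is expected in this assay, and the range is kept wide.

Compound 3 is therefore estimated at 11000 nM, with a range from 3500 nM to 35000 nM. The expected step of a 1.1-fold lower number from compound 2 to compound 3 (0.04 log units; within the scatter) is meant to stay within the usual scatter.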

Compound 3, half-maximal effective concentration: 2600 nM
For compound 3 the middle estimate is 4.2-fold (0.63 log units) above the measured one; measured number below the stated range.
By their numbers in this assay, from the lowest: compound 3; then compound 2; then compound 1.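

In this assay the ring at the far end of the shared core proves to be a place that matters: going from phenyl to 3-nitrophenyl gives a 4.6-fold lower number from compound 2 to compound 3 (0.66 log units; beyond the scatter), a modest change but a real one. Among these compounds, the earlier compounds could not show this, since their only step, a 2.3-fold lower number from compound 1 to compound 2 (0.35 log units; beyond the scatter), was made on the nitrogen on the other aromatic ring, so the number now moves in the same direction from two separate parts of the molecule. Nothing measured here explains how the nitro group brings this about.

The compounds shown cover only one group at this spot, so it remains open whether the lower number belongs to the nitro group itself or whether an amine, a nitrile or a methoxy group in the same place would do the same. Going by these compounds, it is also open whether the nitro group would give a similar step without the (thiophen-2-yl)carbonyl, on the core of compound 1, which would show whether the two changes act independently of each other.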